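Working notes: from compound 2 to compound 4

The source may report more compounds than this note shows. Statements on the series, on what has been measured and on what is new or still open speak of the compounds shown alone.

In a functional assay on BT-474 cells (Homo sapiens) for inhibition, read by fluorescence, with a stated time of 72 h (a higher number here means a weaker inhibitor of growth, a lower number a stronger inhibitor of growth), compound 1 `N[C@H]1CC[C@H](Nc2nc(Nc3ccc(Cl)cc3)c3ncn(C4CCCCC4)c3n2)CC1` gives 4100 nM and compound 2 `COc1cc(Nc2nc(N[C@H]3CC[C@H](N)CC3)nc3c2ncn3CCC(C)C)cc(OC)c1` gives 5900 nM, so these two stand within the scatter of each other. Going by the values given here, compound 3 `CCCCn1cnc2c(Nc3cc(OC)cc(OC)c3)nc(N[C@H]3CC[C@H](N)CC3)nc21` gives 15600 nM, the only number clearly apart from compound 2.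

The next compound is compound 4 `CC(C)CCn1cnc2c(Nc3ccc(O)cc3)nc(N[C@H]3CC[C@H](N)CC3)nc21`, which differs from compound 2 by 4-hydroxyphenyl in place of 3,5-dimethoxyphenyl on a nitrogen on an aromatic ring. In words, this is 4-hydroxyphenyl in place of 3,5-dimethoxyphenyl on a nitrogen on an aromatic ring.

Among the compounds with values here, the one measured step is a 2.6-fold higher number from compound 2 to compound 3 (0.42 log units; beyond the scatter). It is modest and lies beyond the scatter, but it is hydrogen in place of methyl on a saturated chain carbon and leaves the group on that nitrogen untouched. Within the data shown here, no measured step therefore tests this change directly. Compound 1, at 4100 nM, carries another group on that nitrogen and still stands within the scatter of compound 2. It differs in other places too, so it gives only weak support for a small effect.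

On these data alone, no step beyond the scatter is expected in this assay, and the direction remains open. The expected step is a 1.2-fold higher number from compound 2 to compound 4 (0.07 log units; within the scatter). Compound 4 is estimated at 7000 nM, with an expected range of 2000 nM to 20000 nM.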

Compound 4, concentration for 50% growth inhibition: 7700 nM
Compound 4: the middle estimate sits 1.1-fold (0.04 log units) below what was measured; the measured number falls inside the stated range.
By their numbers in this assay, from the lowest: compounds 1, 2 and 4 (each within the scatter of the next); then compound 3.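

In this assay the group on the nitrogen on an aromatic ring now has a direct test, and a 1.3-fold higher number from compound 2 to compound 4 (0.12 log units; within the scatter) shows that 4-hydroxyphenyl in place of 3,5-dimethoxyphenyl does not separate the pair, although the entering group has fewer heavy atoms and brings a hydrogen-bond donor that the leaving group lacks. Of the two steps from compound 2, the one on the saturated chain, a 2.6-fold higher number from compound 2 to compound 3 (0.42 log units; beyond the scatter), lies beyond the scatter, while this exchange on the aromatic group stays within it, so across these compounds the aromatic group tolerates a change of both its substituents and their placement without a readable shift. Nothing measured here accounts for this tolerance.

Going by these compounds alone, the single exchange alters the substituents and their placement together, so the contribution of each stays unresolved, and whether the same exchange would read alike with the butyl chain of compound 3 is also unknown. On these data alone, what an amine or a carboxylic acid in place of the hydroxy group would do in this assay remains open.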